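The source may report more compounds than this note shows. Statements on the series, on what has been measured and on what is new or still open speak of the compounds shown alone.

In a functional assay on T47D cells (Homo sapiens) for cytotoxicity, read by CCK-8 assay and cell counting, with a stated time of 72 h (on this read-out lower numbers stand for stronger inhibition and higher numbers for weaker inhibition), compound 1 `COc1cc(OC)cc(-c2cc3ccccc3c(-c3cccc(O)c3)n2)c1` gives 760 nM. Compound 2 `COc1cccc(-c2nc(-c3ccc(OC)c(OC)c3)cc3cc(C)ccc23)c1` gives 7860 nM in this assay, the higher of the two numbers and set apart from compound 1 by a gap beyond the usual scatter. Compound 3 `COc1ccc(-c2nc(-c3ccc(OC)c(OC)c3)cc3cc(C)ccc23)cc1` differs from compound 2 in a single place: 4-methoxyphenyl in place of 3-methoxyphenyl on an aromatic carbon. Within the data shown here, no step of this kind has been measured here, so the direction is open. The step is expected to be a 1.3-fold lower number from compound 2 to compound 3 (0.12 log units; within the scatter), within the scatter or only a little beyond it. Compound 3 is therefore estimated at 6000 nM in this assay, with a likely range from 2000 nM to 18000 nM.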

Compound 3, half-maximal inhibitory concentration: 3340 nM
Beside the measured number, compound 3's estimate is 1.8-fold (0.25 log units) above it; the range from low to high includes it.
By their numbers in this assay, from the lowest: compound 1; then compound 3; then compound 2.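

In this assay, 4-methoxyphenyl in place of 3-methoxyphenyl on the aromatic carbon next to the ring nitrogen gives a 2.4-fold lower number from compound 2 to compound 3 (0.37 log units; beyond the scatter), a modest step. With the same atoms joined differently, the read-out at this position thus depends on where the methoxy group sits on the phenyl ring. Nothing measured here accounts for this difference. The compounds shown leave open whether an amine or a carboxylic acid in place of the methoxy group would move the number the same way. They also leave open whether the same change would hold on the core of compound 1.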